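This account rests on a few compounds, and the source may have more. Where it says the series, first, only, none or still open, it means among the compounds named here.

Measured in a functional assay on HT cells (Homo sapiens) for antiproliferative activity, read by fluorescence, with a stated time of 72 h; on this read-out higher numbers stand for weaker inhibition of growth and lower numbers for stronger inhibition of growth:
compound 1 `CC(C)c1n[nH]c2c(NCc3ccc(-c4ccccn4)cc3)nc(SCC(N)CN)nc12`: 480 nM
compound 2 `CC(C)c1n[nH]c2c(NCc3ccc(-c4ccccn4)cc3)nc(SCC(O)C(F)(F)F)nc12`: 690 nM
compound 3 `CC(C)c1n[nH]c2c(NCc3ccc(-c4ccccn4)cc3)nc(SCCCN(C)C)nc12`: 105 nM

Compound 3 has the lowest number of the three, and its steps to both others lie beyond the scatter. Compound 4 `CC(C)c1n[nH]c2c(NCc3ccc(-c4ccccn4)cc3)nc(SCCNC(N)=O)nc12` carries ureido in place of (dimethylamino)methyl on a saturated chain carbon, two bonds along the chain from a sulfur. Among the measured compounds shown here, no measured step makes this exact change. The closest guides are the two side-chain changes that end at compound 3: a 4.6-fold lower number from compound 1 to compound 3 (0.66 log units; beyond the scatter) and a 6.6-fold lower number from compound 2 to compound 3 (0.82 log units; beyond the scatter). Both are modest, so a step of similar size, towards a higher number in this assay, is expected on losing that group. The expected step is a 3.8-fold higher number from compound 3 to compound 4 (0.58 log units; beyond the scatter). For compound 4 the estimated value is 400 nM, with an expected range from 130 nM to 1100 nM.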

Compound 4, concentration for 50% growth inhibition: 240 nM
For compound 4 the middle estimate is 1.7-fold (0.22 log units) above the measured one, and the stated range covers the measured number.
By their numbers in this assay, from the lowest: compound 3; then compounds 4, 1 and 2 (each within the scatter of the next, the first and the last beyond it).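

In this assay, the change gives a 2.3-fold higher number from compound 3 to compound 4 (0.36 log units; beyond the scatter), so a chain ending in ureido, with no dimethylamino group, stays within a modest step of compound 3. The ureido chain also gives a 2.9-fold lower number from compound 2 to compound 4 (0.46 log units; beyond the scatter), whereas a 2.0-fold lower number from compound 1 to compound 4 (0.30 log units; within the scatter) leaves compound 1 and compound 4 with no order between them. No measurement here explains these differences.

Going by these compounds, the change from 3-(dimethylamino)propyl to 2-ureidoethyl alters both chain length and end group, so their separate contributions remain unknown. A 3-ureidopropyl chain or a 2-(dimethylamino)ethyl chain on sulfur would separate them.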